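The source may report more compounds than this note shows. Statements on the series, on what has been measured and on what is new or still open speak of the compounds shown alone.

Measured compounds:

Compound 1, `COc1nc(C)c(Nc2nc(Cl)cn([C@H](COC(C)=O)C3CC3)c2=O)cc1C`, in an assay on frontal cortex for displacement of a labelled ligand from corticotropin-releasing factor receptor 1 (Rattus norvegicus), with a stated time of 2 h (a lower number here means a stronger inhibitor, a higher number a weaker inhibitor), gives 5.3 nM.
Compound 2, `COc1nc(C)c(Nc2nc(Cl)cn([C@H](COC(=O)Nc3ccc(Cl)cc3Cl)C3CC3)c2=O)cc1C`, gives 1.7 nM.
Compound 3, `COc1nc(C)c(Nc2nc(Cl)cn([C@H](COC(=O)Nc3cccnc3)C3CC3)c2=O)cc1C`, gives 10 nM.

Compound 3 has the highest number of the three. Its nearest neighbour is compound 1, with a 1.9-fold higher number from compound 1 to compound 3 (0.28 log units; within the scatter), so the two cannot be told apart; the gap to compound 2, a 5.9-fold higher number from compound 2 to compound 3 (0.77 log units; beyond the scatter), is real, as is a 3.1-fold lower number from compound 1 to compound 2 (0.49 log units; beyond the scatter).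

Compound 4, `COc1nc(C)c(Nc2nc(Cl)cn([C@H](COc3cccnc3)C3CC3)c2=O)cc1C`, carries the change (pyridin-3-yl in place of (pyridin-3-yl)carbamoyl on an oxygen on a saturated carbon). The carbamate linker of compound 3 is thus removed and the pyridine ring sits directly on the oxygen. Among the measured compounds shown here, none of the measured steps makes exactly this cut: the three steps above only swap what hangs on the carbonyl carbon or on the amide-type nitrogen, and all of them stay within a modest span. The shared core, with its cyclopropyl-bearing side chain, is unchanged, and a small, uncharged group sits at the same position in every compound. On that basis the step of a 1.4-fold lower number from compound 3 to compound 4 (0.15 log units; within the scatter) is expected to be small, with no clear direction beyond the scatter. Compound 4 is therefore estimated at 7 nM, within a range of 2 nM to 25 nM.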

Compound 4, half-maximal inhibitory concentration: 6.7 nM
For compound 4 the middle estimate is 1.0-fold (0.02 log units) above the measured one; the range from low to high includes it.
By their numbers in this assay, from the lowest: compound 2; then compounds 1, 4 and 3 (each within the scatter of the next).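

In this assay, taking away the carbonyl and the amide hydrogen of the (pyridin-3-yl)carbamoyl group, so that pyridin-3-yl sits directly on the oxygen, gives a step within the scatter, a 1.5-fold lower number from compound 3 to compound 4 (0.17 log units; within the scatter), which shows that this linker can go without a measurable loss at this position. The step from the small acetyl group is also within the scatter, a 1.3-fold higher number from compound 1 to compound 4 (0.10 log units; within the scatter), so acetyl, (pyridin-3-yl)carbamoyl and pyridin-3-yl on this oxygen cannot be told apart, while the (2,4-dichlorophenyl)carbamoyl group of compound 2 stands apart from pyridin-3-yl, with a 3.9-fold higher number from compound 2 to compound 4 (0.60 log units; beyond the scatter). Nothing in the data accounts for why these different groups give such similar results.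

As far as these compounds go, it remains open whether the stronger result of compound 2 comes from the 2,4-dichlorophenyl ring alone or needs the carbamoyl link as well, a question that a 2,4-dichlorophenyl ring placed directly on the oxygen would help to settle. From the compounds shown here alone, how this position would respond to an amine, a carboxylic acid or a longer chain in place of the ring also remains unknown.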